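From phenylsulfonyl to (4-methylphenyl)sulfonyl on the shared core

The compounds below may be only part of what the source reports. "The series", "measured", "known", "first", "only" and "open" are said of these compounds alone.

In a functional assay on QGY-7703 cells (Homo sapiens) for cytotoxicity, read by MTT assay, with a stated time of 24 h (a higher number here means a weaker inhibitor, a lower number a stronger inhibitor), compound 3 `O=C1/C(=C/c2cccnc2)CN(S(=O)(=O)c2ccccc2)C/C1=C\c1ccccc1F` gives 4800 nM. This value lies within the scatter of the other two measured compounds. Compound 1 `CN1C/C(=C\c2cccnc2)C(=O)/C(=C/c2ccccc2F)C1`, with methyl on the amine nitrogen in the ring, gives 4470 nM, and compound 2 `O=C1/C(=C/c2cccnc2)CNC/C1=C\c1ccccc1F`, with hydrogen there, gives 8890 nM.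

Compound 4 `Cc1ccc(S(=O)(=O)N2C/C(=C\c3cccnc3)C(=O)/C(=C/c3ccccc3F)C2)cc1` differs from compound 3 in one place: methyl in place of hydrogen on an aromatic carbon. This is methyl in place of hydrogen on an aromatic carbon, para to a large group. Going by the values given here, no measured step tests that aromatic position. The closest evidence comes from the amine nitrogen, with a 1.1-fold higher number from compound 1 to compound 3 (0.03 log units; within the scatter), a 1.9-fold lower number from compound 2 to compound 3 (0.27 log units; within the scatter) and a 2.0-fold higher number from compound 1 to compound 2 (0.30 log units; within the scatter). Each of these lies within the scatter, even though two of them exchange the entire phenylsulfonyl group. The addition here is smaller, so the expected outcome in this assay is no step beyond the scatter, an estimated 1.1-fold lower number from compound 3 to compound 4 (0.03 log units; within the scatter). For compound 4 the expected value is 4500 nM, within an estimated range of 2200 nM to 9000 nM.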

Compound 4, half-maximal inhibitory concentration: 9700 nM
Compound 4: the middle estimate sits 2.2-fold (0.33 log units) below what was measured; the whole stated range lies below it.
By their numbers in this assay, from the lowest: compounds 1, 3, 2 and 4 (each within the scatter of the next, the first and the last beyond it).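

In this assay, this aromatic position responds to a single added methyl with a modest step beyond the scatter (a 2.0-fold higher number from compound 3 to compound 4 (0.31 log units; beyond the scatter)), whereas the exchanges on the amine nitrogen among compounds 1, 2 and 3 all stayed within it. The (4-methylphenyl)sulfonyl group also separates from methyl on the nitrogen (a 2.2-fold higher number from compound 1 to compound 4 (0.34 log units; beyond the scatter)) but not from hydrogen there (a 1.1-fold higher number from compound 2 to compound 4 (0.04 log units; within the scatter)), so the phenylsulfonyl and (4-methylphenyl)sulfonyl groups do not behave alike in this assay. Nothing available explains why the added methyl raises the number.

From the compounds shown here alone, whether a chlorine atom, a methoxy group or a longer chain such as ethyl on that aromatic ring would shift the number in the same direction remains open. So does whether this modest step would recur on a core carrying different aromatic groups.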